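Chalcone notes: swapping the aryl group on compound 2

The source may hold more compounds than are shown below. What is called first, only, known or untested is meant among the compounds shown, and "the series" means these compounds.

Measured in a functional assay on CNE-2 cells (Homo sapiens) for cytotoxicity, read by sulforhodamine B assay, with a stated time of 48 h; a lower number here means a stronger inhibitor, a higher number a weaker inhibitor:
- compound 1 `O=C(/C=C/c1cccc(Br)c1)c1cccc(-c2cccc(F)c2)c1`: 6550 nM
- compound 2 `COc1ccc(-c2cc(C(=O)/C=C/c3cc(OC)c(OC)c(OC)c3)ccc2N)cc1OC`: 4330 nM
- compound 3 `COc1ccc(/C=C/C(=O)c2cccc(Br)c2)cc1`: "not determined" (no result reported)

Within the data shown here, compound 2 at 4330 nM and compound 1 at 6550 nM lie within the scatter of each other, and these are the only two numbers. Compound 4 `COc1cc(/C=C/C(=O)c2ccc(N)c(-c3ccc(F)cc3)c2)cc(OC)c1OC` carries 4-fluorophenyl in place of 3,4-dimethoxyphenyl on an aromatic carbon, ortho to an amino group: 4-fluorophenyl in place of 3,4-dimethoxyphenyl on an aromatic carbon. Among the measured compounds shown here, no measured step between compounds that differ in one place is available to size this change. With so little to go on, no shift beyond the scatter is expected in this assay, and the expected step is a 1.1-fold lower number from compound 2 to compound 4 (0.03 log units; within the scatter). For compound 4 the estimated value is 4000 nM, with an expected range of 1300 nM to 12000 nM.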

Compound 4, half-maximal inhibitory concentration: 4600 nM
Compound 4: middle estimate off by 1.2-fold (0.06 log units), on the low side, within the range that was stated.
By their numbers in this assay, from the lowest: compounds 2, 4 and 1 (each within the scatter of the next).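

In this assay, 4-fluorophenyl in place of 3,4-dimethoxyphenyl on an aromatic carbon, ortho to an amino group, gives a 1.1-fold higher number from compound 2 to compound 4 (0.03 log units; within the scatter). Among these compounds, this is the first one-place step: the group that leaves carries 2 hydrogen-bond acceptors and the group that enters carries 0, yet the number does not shift beyond the scatter. No supporting measurement explains this result.

As far as these compounds go, it remains open whether a carboxylic acid or a morpholine at this position would move the number beyond the scatter. From the compounds shown here alone, the effect of replacing the amino group itself is also open.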